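Bulky aryl in place of methyl: potency expected to fall

The source may hold more compounds than are shown below. What is called first, only, known or untested is meant among the compounds shown, and "the series" means these compounds.

Compound 1 `C=C(Br)C(=O)Nc1ccc(/C=C2\SC(=O)N(Cc3cccc(Cl)c3)C2=O)cc1`: in a functional assay on HeLa cells (Homo sapiens) for cytotoxicity, read by cell counting, with a stated time of 4 days (a higher number here means a weaker inhibitor, a lower number a stronger inhibitor), compound 1 gives 8900 nM.
Compound 2 `C=C(Br)C(=O)Nc1ccc(/C=C2\SC(=O)N(CC)C2=O)cc1`: in this assay compound 2 gives 1400 nM.

Compound 2 holds the lowest of the two numbers, and its nearest neighbour is compound 1, separated by a 6.4-fold lower number from compound 1 to compound 2 (0.80 log units; beyond the scatter). Compound 3 `C=C(Br)C(=O)Nc1ccc(/C=C2\SC(=O)N(Cc3ccc(C(C)(C)C)cc3)C2=O)cc1` differs from compound 2 in this way: 4-(tert-butyl)phenyl in place of methyl on a saturated chain carbon bound to an amide-type nitrogen in a ring. Going by the values given here, the only step that bears on this is the reverse move, a 6.4-fold lower number from compound 1 to compound 2 (0.80 log units; beyond the scatter), a modest change beyond the scatter, so an aromatic ring entering where methyl was is expected to raise the number in this assay. Compound 3 is expected to give 7000 nM, between 2500 nM and 20000 nM. The expected step is a 5.0-fold higher number from compound 2 to compound 3 (0.70 log units; beyond the scatter).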

Compound 3, half-maximal inhibitory concentration: 2700 nM
Compound 3: the middle estimate sits 2.6-fold (0.41 log units) above what was measured, within the range that was stated.
By their numbers in this assay, from the lowest: compounds 2 and 3 (each within the scatter of the next); then compound 1.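

In this assay, putting 4-(tert-butyl)phenyl in place of methyl on this saturated chain carbon leaves the number within the scatter (a 1.9-fold higher number from compound 2 to compound 3 (0.29 log units; within the scatter)), so an aromatic ring at this position does not by itself raise it, as compound 1 alone had suggested. The two aromatic groups do separate (a 3.3-fold lower number from compound 1 to compound 3 (0.52 log units; beyond the scatter)), so the outcome here depends on which aromatic group is present; nothing available explains these numbers.

On these data alone, whether a longer alkyl chain in place of methyl would keep the number within the scatter of compound 2 remains open. So does the effect of an amine or a carboxylic acid on the aromatic ring.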